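The source may hold more compounds than are shown below. What is called first, only, known or untested is meant among the compounds shown, and "the series" means these compounds.

In a functional assay on HCT-116 cells (Homo sapiens) for inhibition, read by MTT assay, with a stated time of 72 h (on this read-out lower numbers stand for stronger inhibition of growth and higher numbers for weaker inhibition of growth), compound 1 `COC1=C(OC)C(=O)C(CCCCCCn2cc(C[C@H](O)COCCOC[C@@H](O)Cc3ccc(-c4ccccc4)cc3)nn2)=C(C)C1=O` gives 5000 nM and compound 2 `O[C@H](COCCOC[C@@H](O)Cc1cn(Cc2cccc(-c3ccccc3)c2)nn1)Cc1ccc(-c2ccccc2)cc1` gives 7200 nM on the same read-out. Within the data shown here, these two values lie within the usual scatter of each other, so compound 2 stands level with the only other number available. Compound 3 `O[C@H](COCCOC[C@@H](O)Cc1cn(Cc2ccc(C(F)(F)F)cc2)nn1)Cc1ccc(-c2ccccc2)cc1` has not yet been measured. It differs from compound 2 in one place, on a saturated chain carbon bound to an aromatic nitrogen, where 4-(trifluoromethyl)phenyl stands in place of 3-phenylphenyl (4-(trifluoromethyl)phenyl in place of 3-phenylphenyl on a saturated chain carbon bound to an aromatic nitrogen). Among the measured compounds shown here, no measured pair shows the effect of such a change, so no step beyond the scatter is expected in this assay and no firm direction can be given. The expected step of a 1.2-fold lower number from compound 2 to compound 3 (0.08 log units; within the scatter) is therefore estimated to stay small. The estimate for compound 3 is 6000 nM with 2500 nM to 15000 nM as the expected range.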

Compound 3, concentration for 50% growth inhibition: 2500 nM
Beside the measured number, compound 3's estimate is 2.4-fold (0.38 log units) above it; low and high end bracket the measured number.
By their numbers in this assay, from the lowest: compounds 3, 1 and 2 (each within the scatter of the next, the first and the last beyond it).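

In this assay the group on a saturated chain carbon bound to an aromatic nitrogen proves able to shift the number: 4-(trifluoromethyl)phenyl in place of 3-phenylphenyl gives a 2.9-fold lower number from compound 2 to compound 3 (0.46 log units; beyond the scatter) and so the only step shown that lies beyond the scatter, though a modest one. The second aromatic ring of 3-phenylphenyl is thus not required at this place for growth inhibition, as a single ring bearing trifluoromethyl, with fewer heavy atoms, gives the lower number. No measurement at hand accounts for this step.

The compounds shown leave open whether the trifluoromethyl group or the loss of the second ring drives the step. They also leave open how an amine, a carboxylic acid or a longer chain at this place would read out.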